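Swapping trifluoromethoxy for hydroxy on compound 2

This account rests on a few compounds, and the source may have more. Where it says the series, first, only, none or still open, it means among the compounds named here.

Compound 1 `COc1ccc(-c2nc(C)nn2-c2cccc(C(=O)NCCCc3ccc(Br)cc3)c2)cc1` gives > 20000 nM (a limit of the assay, not a number)
Compound 2 `CCc1nc(-c2ccc(OC(F)(F)F)cc2)n(-c2cccc(C(=O)NCCCCc3ccccc3)c2)n1` gives 640 nM (a measured number)

Within the data shown here, in a functional assay on PANC-1 cells (Homo sapiens), read by microscopy, crystal violet staining and transwell migration, with a stated time of 18 h, in the presence of a further agent that is not named here (a higher number here means a weaker inhibitor, a lower number a stronger inhibitor), compound 2 holds the only actual number so far (640 nM). Compound 3 `CCc1nc(-c2ccc(O)cc2)n(-c2cccc(C(=O)NCCCCc3ccccc3)c2)n1` has hydrogen in place of trifluoromethyl on an oxygen on an aromatic ring. Among the measured compounds shown here, no measured pair isolates this change, so its size is uncertain. A moderate weakening beyond the scatter is expected, meaning a higher number in this assay for compound 3. The expected change is a 3.9-fold higher number from compound 2 to compound 3 (0.59 log units; beyond the scatter) by this estimate. Compound 3 is estimated at 2500 nM with an expected range of 700 nM to 12000 nM in this estimate.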

Compound 3, half-maximal inhibitory concentration: 220 nM
Compound 3: the middle estimate sits 11-fold (1.06 log units) above what was measured; the measured number lies below the stated range.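

In this assay, hydrogen in place of trifluoromethyl on this oxygen gives a 2.9-fold lower number from compound 2 to compound 3 (0.46 log units; beyond the scatter). Among these compounds, this is the first step that isolates a single change, and it shows that the 4-hydroxyphenyl gives stronger inhibition than the 4-(trifluoromethoxy)phenyl, even with 4 heavy atoms removed. Nothing measured here explains this direction. As far as these compounds go, it remains open whether an ethyl group on this oxygen would keep this gain, and whether an amine in place of the hydroxy would do the same.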